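The source may report more compounds than this note shows. Statements on the series, on what has been measured and on what is new or still open speak of the compounds shown alone.

Measured compounds:
compound 1 `C/C=C/[C@@H](CC(=O)O)NC(=O)[C@@H]1CCCN1S(=O)(=O)c1cc(Cl)cc(Cl)c1` gives 13 nM in an assay on RPMI-8866 cells for inhibition of integrin alpha-4/beta-1 (Homo sapiens); on this read-out lower numbers stand for stronger inhibition and higher numbers for weaker inhibition
compound 2 `O=C(O)C[C@@H](NC(=O)[C@@H]1CCN1S(=O)(=O)c1cc(Cl)cc(Cl)c1)c1ccc(OC(F)F)cc1` gives 1.3 nM in this assay

Of the two measured compounds, compound 1 has the higher number; compound 2 lies a good distance lower, beyond the scatter, but its structure differs from compound 1 in more than one place, so no single cause for that gap can be read from these two values alone.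

Compound 3 `CCOc1ccc([C@@H](CC(=O)O)NC(=O)[C@@H]2CCCN2S(=O)(=O)c2cc(Cl)cc(Cl)c2)cc1` has not yet been measured. It is built from compound 1 by one change: 4-ethoxyphenyl in place of prop-1-en-1-yl on a saturated chain carbon bound to an amide-type nitrogen and a saturated chain carbon. Within the data shown here, no measured pair shows this exact change on this core. Among the measured compounds shown here, still, compound 2 shows that a compound carrying an aromatic group at the corresponding place can reach a low number, and that is the only guide here.

Compound 3 is expected to give a lower number than compound 1, a step of a 4.3-fold lower number from compound 1 to compound 3 (0.64 log units; beyond the scatter) in this assay, with the reasoning resting on compound 2 and its 1.3 nM. The estimate for compound 3 is 3 nM, within a range of 1 nM to 12 nM.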

Compound 3, half-maximal inhibitory concentration: 0.27 nM
The estimate for compound 3 lay 11-fold (1.05 log units) above the measured number; measured number below the stated range.
By their numbers in this assay, from the lowest: compound 3; then compound 2; then compound 1.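

On the saturated chain carbon bound to an amide-type nitrogen and a saturated chain carbon, replacing prop-1-en-1-yl with 4-ethoxyphenyl gives in this assay a large change: a 48-fold lower number from compound 1 to compound 3 (1.68 log units; beyond the scatter). This single-place comparison shows directly that this position strongly affects the read-out and that a substituted aromatic ring can sit there with a much lower number, which the earlier comparison of compound 1 and compound 2 could not show because those structures differ in more than one place. No measurement shown here explains the size of this step.

The ring and the ethoxy group enter together, so their separate shares in the step remain unresolved. On these data alone, it also remains open what a plain phenyl group, a 4-methoxyphenyl group or a 4-aminophenyl group would give at this position on the same core.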